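The source may report more compounds than this note shows. Statements on the series, on what has been measured and on what is new or still open speak of the compounds shown alone.

Measured so far:
- compound 1 `COc1ccccc1N1CCN(CCCOc2ccc(C(=O)Nc3ccccc3OCCCC(=O)O)cc2)CC1`: 41000 nM in an assay on isolated protein for inhibition of steroid 5-alpha-reductase (Rattus norvegicus); a lower number here means a stronger inhibitor, a higher number a weaker inhibitor
- compound 2 `CCc1ccc(C(CCN2CCN(c3ccccc3OC)CC2)Oc2ccc(NC(=O)c3ccccc3OCCCC(=O)O)cc2)cc1`: 130 nM in this assay

Compound 1 stands at the highest of the two numbers in this assay; its nearest neighbour, compound 2, sits far below it, a gap well beyond the usual scatter. Compound 2 carries an aryl group on the chain carbon that bears the aryl ether oxygen, where compound 1 carries only hydrogen.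

Compound 3 `COc1ccccc1N1CCN(CCC(Oc2ccc(C(=O)Nc3ccccc3OCCCC(=O)O)cc2)c2ccc(C)cc2)CC1` is not yet measured. It differs from compound 1 by 4-methylphenyl in place of hydrogen on a saturated chain carbon bound to an oxygen on an aromatic ring and a saturated chain carbon. For the measured compounds named here, no step between measured compounds covers this exact change, so the expectation rests on what compound 1 and compound 2 show: compound 2, with an aryl group at that same chain carbon, gives 130 nM. Accordingly the step in this assay from compound 1 to compound 3 is expected to be large and toward lower numbers, about a 210-fold lower number from compound 1 to compound 3 (2.31 log units; beyond the scatter). Compound 3 is estimated at 200 nM, with a range of 50 nM to 1000 nM.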

Compound 3, half-maximal inhibitory concentration: 67 nM
The estimate for compound 3 lay 3.0-fold (0.47 log units) above the measured number; low and high end bracket the measured number.
By their numbers in this assay, from the lowest: compounds 3 and 2 (each within the scatter of the next); then compound 1.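

In this assay the step of a 610-fold lower number from compound 1 to compound 3 (2.79 log units; beyond the scatter) is a large one, beyond the scatter, and comes from a single change: 4-methylphenyl in place of hydrogen on a saturated chain carbon bound to an oxygen on an aromatic ring and a saturated chain carbon. For the compounds shown here, compound 2 differs from compound 1 in more than one place, so this is the first pair that ties a large drop in the number to this position alone. Nothing measured on these compounds accounts for the size of the step.

From the compounds shown here alone, whether the gain needs the whole 4-methylphenyl group remains open, as a methyl group or an unsubstituted phenyl at this carbon would test that. Also open, going by these compounds, is whether a cyclohexyl group, with no aromatic ring, would give a step of similar size.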